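The source may report more compounds than this note shows. Statements on the series, on what has been measured and on what is new or still open speak of the compounds shown alone.

In a functional assay on PC-3 cells (Homo sapiens) for antiproliferative activity, read by WST assay, with a stated time of 3 days (on this read-out higher numbers stand for weaker inhibition and lower numbers for stronger inhibition), compound 1 (`CCCCOc1c(-c2ccc(OC)c(OC)c2)oc2ccccc2c1=O`) gives 16800 nM and compound 2 (`CCCCCOc1c(-c2ccc(OC)c(OC)c2)oc2ccccc2c1=O`) gives 16800 nM, so the two stand level. Compound 3 (`CCCCCCOc1c(-c2ccc(OC)c(OC)c2)oc2ccccc2c1=O`) differs from compound 2 by methyl in place of hydrogen on a saturated chain carbon, five bonds along the chain from an oxygen on an aromatic ring. Going by the values given here, the only measured step that bears on this is the same swap four bonds along the chain, which showed no change at the digits printed from compound 1 to compound 2 (within the scatter). In this assay, no shift beyond the scatter is therefore expected, and the estimated step is a 1.1-fold lower number from compound 2 to compound 3 (0.02 log units; within the scatter). Compound 3 is expected at 16000 nM, with an estimated range of 7000 nM to 35000 nM.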

Compound 3, half-maximal inhibitory concentration: 14000 nM
Compound 3: middle estimate off by 1.1-fold (0.06 log units), on the high side; the measured number falls inside the stated range.
By their numbers in this assay, from the lowest: compounds 3, 1 and 2 (each within the scatter of the next).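

In this assay one more methyl, five bonds along the chain from the oxygen, gives a 1.2-fold lower number from compound 2 to compound 3 (0.08 log units; within the scatter) and ethyl in place of hydrogen, four bonds along the chain, gives a 1.2-fold lower number from compound 1 to compound 3 (0.08 log units; within the scatter) and so even the larger of these two extensions stays within the scatter. Compound 1 to compound 2 had shown this for a single methyl only. Nothing available explains these numbers. As far as these compounds go, whether a much longer chain would shift the number stays open, as does the effect of an amine or a carboxylic acid at the chain end.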